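The source may hold more compounds than are shown below. What is called first, only, known or untested is meant among the compounds shown, and "the series" means these compounds.

Series notes. Compounds 1 to 3 share one core and differ only in the group on a triple-bonded carbon. In an assay on CHO cells for displacement of a labelled ligand from adenosine receptor A3 (Homo sapiens), read by scintillation counting, with a stated time of 60 min (on this read-out lower numbers stand for stronger inhibition and higher numbers for weaker inhibition), compound 1 `CNC(=O)[C@@]12C[C@@H]1[C@@H](n1cnc3c(NC)nc(C#Cc4ccccc4OC)nc31)[C@H](O)[C@@H]2O` gives 0.77 nM, compound 2 `CNC(=O)[C@@]12C[C@@H]1[C@@H](n1cnc3c(NC)nc(C#Cc4ccc(CO)cc4)nc31)[C@H](O)[C@@H]2O` gives 2.16 nM, and compound 3 `CNC(=O)[C@@]12C[C@@H]1[C@@H](n1cnc3c(NC)nc(C#Cc4cnn(C)c4)nc31)[C@H](O)[C@@H]2O` gives 2.34 nM. Compound 3 stands at the highest of the three numbers in this assay; its gap to compound 2 lies within the scatter, while a 2.8-fold higher number from compound 1 to compound 2 (0.45 log units; beyond the scatter) and a 3.0-fold higher number from compound 1 to compound 3 (0.48 log units; beyond the scatter) are modest steps beyond it, and a 1.1-fold higher number from compound 2 to compound 3 (0.03 log units; within the scatter) is within the scatter.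

Compound 4 `CNC(=O)[C@@]12C[C@@H]1[C@@H](n1cnc3c(NC)nc(C#CC4CCCCC4)nc31)[C@H](O)[C@@H]2O` carries the change (cyclohexyl in place of 1-methyl-1H-pyrazol-4-yl on a triple-bonded carbon). All three measured steps vary the group on the triple-bonded carbon, and the two steps beyond the scatter both raise the number modestly; the exchange of a six-membered aromatic ring for a five-membered aromatic ring with 2 hetero atoms changed nothing beyond the scatter. Among the measured compounds shown here, no measured step puts a six-membered non-aromatic ring of carbon only at this place, so the direction rests on the modest size of the steps seen so far. A step of no more than modest size is therefore expected, a 1.9-fold higher number from compound 3 to compound 4 (0.28 log units; within the scatter). For compound 4 in this assay the estimate is 4.5 nM, with a range from 1.5 nM to 14 nM.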

Compound 4, inhibition constant: 1.68 nM
Compound 4: the middle estimate sits 2.7-fold (0.43 log units) above what was measured; measured number inside the range.
By their numbers in this assay, from the lowest: compound 1; then compounds 4, 2 and 3 (each within the scatter of the next).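

In this assay, a non-aromatic ring of carbon only on the triple-bonded carbon fits among the aromatic groups: cyclohexyl gives a 1.4-fold lower number from compound 3 to compound 4 (0.14 log units; within the scatter) and a 1.3-fold lower number from compound 2 to compound 4 (0.11 log units; within the scatter), so at this position, across these compounds, neither an aromatic ring nor the 2 hydrogen-bond acceptors of 1-methyl-1H-pyrazol-4-yl are needed for a number of this size. The 2-methoxyphenyl group of compound 1 remains apart, with a 2.2-fold higher number from compound 1 to compound 4 (0.34 log units; beyond the scatter), and compound 1 now has the lowest number of the four, with all its steps beyond the scatter. Nothing at hand gives a reason for these numbers.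

Open, on these data alone, is whether an open carbon chain such as n-butyl, or an amine or a carboxylic acid carried on the cyclohexyl ring, would stay in this range. A plain phenyl would show whether the low number of compound 1 goes with its methoxy group.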